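This account rests on a few compounds, and the source may have more. Where it says the series, first, only, none or still open, it means among the compounds named here.

The account follows the shared core from compound 2 `Cc1nc(C(=O)N[C@H]2CC[C@H](C)CC2)c(C)c(-c2ccc3c(c2)NCCO3)c1[C@H](OC(C)(C)C)C(=O)O` to compound 3 `Cc1nc(C(=O)N[C@H]2CC[C@H](C)CC2)c(C)c(-c2ccc3c(c2C)NCCO3)c1[C@H](OC(C)(C)C)C(=O)O`. In an ADME assay on microsomes from liver (Homo sapiens) for metabolic stability (a lower number here means that the compound disappears faster, a higher number that the compound lasts longer), compound 1 `Cc1nc(C(=O)N[C@H]2CC[C@H](C)CC2)c(C)c(-c2ccc(Cl)cc2)c1[C@H](OC(C)(C)C)C(=O)O` gives 3.07 h. In this assay compound 2 reaches the limit of the assay, > 5 h, so only a floor is known for it. One of the two values shown sits at that limit (the limit of > 5 h in this assay, at which 1 of the 2 values shown sits). The step of an at least 1.6-fold higher number from compound 1 to compound 2 (0.21 log units; that floor lies within the scatter) is the only measured one, and it concerns an exchange of a different kind. Compound 3 differs from compound 2 by methyl in place of hydrogen on an aromatic carbon. For the measured compounds named here, no measured step shares this change, so there is no basis for expecting movement in this assay in either direction beyond the scatter. The estimate for compound 3 is therefore 6 h, between 3 h and 12 h. This means an expected step that the limit leaves unreadable from compound 2 to compound 3 from compound 2 to compound 3. The chance that compound 3 likewise returns only the limit is judged high.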

Compound 3, half-life: 3.12 h
Estimate against measurement, compound 3: 1.9-fold (0.28 log units) above; measured number inside the range.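

In this assay, methyl in place of hydrogen on this aromatic carbon gives the first step read at this position, an at least 1.6-fold lower number from compound 2 to compound 3 (0.20 log units; that floor lies within the scatter). The exchange from the group on compound 1 to the methyl-bearing group of compound 3 gives a 1.0-fold higher number from compound 1 to compound 3 (0.01 log units; within the scatter), so this larger group now has a measured number rather than only a floor. How far the methyl step truly reaches cannot be read, because one end of it rests on a limit: the limit of > 5 h in this assay, at which 1 of the 3 values shown sits.

The compounds shown leave open whether another group on this same aromatic carbon, such as fluoro or methoxy, would give a number like that of compound 3 in this assay. They also leave open whether methyl would give any step on the chlorine-bearing aromatic ring of compound 1.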